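Compound 2 to compound 3: methyl in place of fluoro

The source may hold more compounds than are shown below. What is called first, only, known or untested is meant among the compounds shown, and "the series" means these compounds.

In a functional assay on A2780 cells (Homo sapiens) for antiproliferative activity, read by resazurin assay, with a stated time of 72 h (a higher number here means a weaker inhibitor, a lower number a stronger inhibitor), compound 1 (`CN(Cc1cccc(F)c1)C(=O)c1cc2c(Cc3ccccc3)n[nH]c2cc1O`) gives 5000 nM and compound 2 (`CN(Cc1ccc(F)cc1)C(=O)c1cc2c(Cc3ccccc3)n[nH]c2cc1O`) gives 4100 nM on the same shared core. Going by the values given here, compound 2 stands level with compound 1, the only other measured member of the series, since the step of a 1.2-fold lower number from compound 1 to compound 2 (0.09 log units; within the scatter) does not separate them.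

Compound 3 (`Cc1ccc(CN(C)C(=O)c2cc3c(Cc4ccccc4)n[nH]c3cc2O)cc1`) carries methyl in place of fluoro on an aromatic carbon, para to a large group (methyl in place of fluoro on an aromatic carbon), turning 4-fluorobenzyl into 4-methylbenzyl. Among the compounds with values here, no measured step makes this exchange, so the evidence is indirect. Within the data shown here, the one step that touches the same ring is a 1.2-fold lower number from compound 1 to compound 2 (0.09 log units; within the scatter) and it gives only a weak guide to size. On that basis no step beyond the scatter is expected in this assay and no direction can be favoured with any confidence. The expected step is a 1.1-fold higher number from compound 2 to compound 3 (0.04 log units; within the scatter) as a working estimate. For compound 3 the estimated value is 4500 nM with an expected range from 2200 nM to 9000 nM in this read-out.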

Compound 3, half-maximal inhibitory concentration: 6900 nM
Beside the measured number, compound 3's estimate is 1.5-fold (0.19 log units) below it; the range from low to high includes it.
By their numbers in this assay, from the lowest: compounds 2, 1 and 3 (each within the scatter of the next).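

In this assay, the exchange of fluoro for methyl on an aromatic carbon, para to a large group, gives a 1.7-fold higher number from compound 2 to compound 3 (0.23 log units; within the scatter), so swapping one heavy atom for another at this place, with no hydrogen-bond donor or acceptor on either side, does not separate the pair. The earlier compounds shown here showed only a shift of fluoro on the ring, whereas the change from 3-fluorophenyl to 4-methylphenyl now gives a 1.4-fold higher number from compound 1 to compound 3 (0.14 log units; within the scatter), so a non-fluorine group also leaves the number level with both fluorinated compounds. No measurement is available that bears on why fluoro and methyl read alike here.

The compounds shown leave open whether any group at this place can move the number beyond the scatter, since they cover only fluoro and methyl and give no reading for an amine, a carboxylic acid or a longer chain such as butyl. They also leave open whether changes elsewhere on the shared core would do more than changes on this ring.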